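The source may hold more compounds than are shown below. What is called first, only, known or untested is meant among the compounds shown, and "the series" means these compounds.

Compounds sharing one core differ here only in the chain that ends in hydroxycarbamoyl. In a functional assay on MDA-MB-231 cells (Homo sapiens) for inhibition, read by MTT assay, with a stated time of 72 h (on this read-out lower numbers stand for stronger inhibition and higher numbers for weaker inhibition), compound 1 `Nc1nc2cc(-c3nn(CCCC(=O)NO)c4ncnc(N)c34)ccc2o1` gives 19500 nM and compound 3 `Nc1nc2cc(-c3nn(CCCCC(=O)NO)c4ncnc(N)c34)ccc2o1` gives 21200 nM. These two values lie within the scatter of each other, so compound 3 stands level with compound 1. Compound 2 `Nc1nc2cc(-c3nn(CCC(=O)NO)c4ncnc(N)c34)ccc2o1` reads > 50000 nM, which is a limit of the assay.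

Compound 4 `Nc1nc2cc(-c3nn(CCCCCC(=O)NO)c4ncnc(N)c34)ccc2o1` lengthens the chain of compound 3: (hydroxycarbamoyl)methyl in place of hydroxycarbamoyl on a saturated chain carbon, four bonds along the chain from an aromatic nitrogen. Here (hydroxycarbamoyl)methyl stands in place of hydroxycarbamoyl on a saturated chain carbon, four bonds along the chain from an aromatic nitrogen.

Changes of the same kind have already been measured. Shortening the chain gave an at least 2.5-fold higher number from compound 1 to compound 2 (0.40 log units; beyond the scatter), and the wider jump gave an at least 2.3-fold lower number from compound 2 to compound 3 (0.37 log units; beyond the scatter). For the measured compounds named here, the closest precedent, a lengthening, gave a 1.1-fold higher number from compound 1 to compound 3 (0.04 log units; within the scatter). That last step suggests no change beyond the scatter in this assay, and the expected step is a 1.2-fold lower number from compound 3 to compound 4 (0.07 log units; within the scatter). For compound 4 the estimated value is 18000 nM, with an expected range from 7000 nM to 45000 nM.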

Compound 4, half-maximal inhibitory concentration: 19000 nM
Compound 4: middle estimate off by 1.1-fold (0.02 log units), on the low side; the measured number falls inside the stated range.
By their numbers in this assay, from the lowest: compounds 4, 1 and 3 (each within the scatter of the next). At a limit, above all of these: compound 2.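

In this assay, the (hydroxycarbamoyl)methyl change at this position, four bonds along the chain from an aromatic nitrogen, produces no step beyond the scatter: a 1.1-fold lower number from compound 3 to compound 4 (0.05 log units; within the scatter), and a 1.0-fold lower number from compound 1 to compound 4 (0.01 log units; within the scatter). Compounds 1, 3 and 4 therefore read level across three chain lengths, while compound 2, with the shortest chain and a value that is a limit, stays apart, with an at least 2.6-fold lower number from compound 2 to compound 4 (0.42 log units; beyond the scatter). Whether the same change truly has a different size at different chain lengths remains unsettled: the same change on two cores in this assay, an at least 2.3-fold lower number (0.37 log units; beyond the scatter) from compound 2 to compound 3 and a 1.0-fold lower number (0.01 log units; within the scatter) from compound 1 to compound 4; the limit leaves it open whether they differ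

The compounds shown leave open whether a longer chain than that of compound 4 would still read level with compounds 1, 3 and 4. They also leave open whether a carboxylic acid in place of hydroxycarbamoyl at the chain end would give a similar number.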